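Swapping a para methoxy for chloro on the aryl group

The source may hold more compounds than are shown below. What is called first, only, known or untested is meant among the compounds shown, and "the series" means these compounds.

Measured so far:
compound 1 `CC[C@H](NC(=O)c1c(CN2CCC(N3CCCCC3)CC2)c(-c2cccc(C(F)(F)F)c2)nc2ccccc12)c1ccccc1` gives 6 nM
compound 2 `COc1ccc(-c2nc3ccccc3c(C(=O)N[C@@H](C)c3ccccc3)c2CN2CCC(N3CCCCC3)CC2)cc1` gives 320 nM
compound 3 `CC(C)[C@H](NC(=O)c1c(CN2CCC(N3CCCCC3)CC2)c(-c2cccc(C(F)(F)F)c2)nc2ccccc12)c1ccccc1` gives 25 nM

All three were tested in an assay on cells for antagonist activity at transient receptor potential cation channel subfamily V member 4 (Rattus norvegicus), read by FLIPR and calcium flux, with a stated time of 10 min; a lower number here means a stronger inhibitor, a higher number a weaker inhibitor. Compound 2 stands highest of the three numbers, so it is the weakest inhibitor shown: compound 3 sits a good way below it, and compound 1 is further still below. Within the data shown here, the only step that changes one place is a 4.2-fold higher number from compound 1 to compound 3 (0.62 log units; beyond the scatter), a change on the side chain; it does not touch the aryl group.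

Compound 4 `C[C@H](NC(=O)c1c(CN2CCC(N3CCCCC3)CC2)c(-c2ccc(Cl)cc2)nc2ccccc12)c1ccccc1` differs from compound 2 by chloro in place of methoxy on an aromatic carbon. Among the measured compounds shown here, no measured pair isolates this change, and compounds 1 and 3 differ from compound 2 in two places at once, so their gap to compound 2 cannot be assigned to the aryl group alone. The expectation in this assay is therefore uncertain, with a moderate lowering of the number thought most likely and a wide range allowed.

Compound 4 is estimated at 100 nM (range 20 nM to 500 nM), a step of a 3.2-fold lower number from compound 2 to compound 4 (0.51 log units; beyond the scatter) expected.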

Compound 4, half-maximal inhibitory concentration: 16 nM
Beside the measured number, compound 4's estimate is 6.3-fold (0.80 log units) above it; the whole stated range lies above it.
By their numbers in this assay, from the lowest: compound 1; then compounds 4 and 3 (each within the scatter of the next); then compound 2.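

In this assay, the change from 4-methoxyphenyl to 4-chlorophenyl gives a 20-fold lower number from compound 2 to compound 4 (1.30 log units; beyond the scatter), and this is the first pair shown that isolates the aryl group. It marks this aromatic carbon, para to a large group, as a place where a single swap weighs heavily, more so than the side-chain change that gave a 4.2-fold higher number from compound 1 to compound 3 (0.62 log units; beyond the scatter). Nothing available explains why this swap has so large an effect.

The pair cannot separate what chloro adds from what the loss of methoxy removes; plain hydrogen, fluoro or bromo at this place would help to tell these apart. Among these compounds, it also remains open whether the same swap would have as large an effect alongside the other side chains, such as the one in compound 1.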